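The source may report more compounds than this note shows. Statements on the series, on what has been measured and on what is new or still open speak of the compounds shown alone.

Compound 1 `O=C(NCc1ccc(S(=O)(=O)c2ccccc2)cc1)NCc1cccnc1`: 10000 nM
Compound 2 `O=C(NCc1ccc(S(=O)(=O)c2ccccc2)cc1)N1Cc2ccncc2C1`: 115000 nM

In a physicochemical assay for solubility, in phosphate buffer, with a stated time of 24 h, at pH 7.4, tested at 100 uM (on this read-out higher numbers stand for higher solubility and lower numbers for lower solubility), compound 2 has the highest of the two numbers, at 115000 nM. Within the data shown here, the only measured step is a 12-fold higher number from compound 1 to compound 2 (1.06 log units; beyond the scatter), a large one.

Compound 3 `CCCn1cc(S(=O)(=O)c2ccc(CNC(=O)N3Cc4ccncc4C3)cc2)cn1` keeps the rest of compound 2 but has 1-propyl-1H-pyrazol-4-yl in place of phenyl on a sulfonyl sulfur. Among the measured compounds shown here, the measured step was made on a carbonyl carbon, a different place, and no measured pair shows a change on the sulfonyl sulfur. Its size therefore cannot be carried over to this change, and the data give no direction for it. With nothing to point to a large shift, no step beyond the scatter is expected in this assay. The estimated step is a 1.4-fold lower number from compound 2 to compound 3 (0.13 log units; within the scatter). For compound 3 the expected value is 85000 nM, with an estimated range of 35000 nM to 140000 nM.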

Compound 3, solubility: 105000 nM
Estimate against measurement, compound 3: 1.2-fold (0.09 log units) below; the measured number falls inside the stated range.
By their numbers in this assay, from the lowest: compound 1; then compounds 3 and 2 (each within the scatter of the next).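

In this assay, the sulfonyl sulfur now has a measured pair: 1-propyl-1H-pyrazol-4-yl in place of phenyl gives a 1.1-fold lower number from compound 2 to compound 3 (0.04 log units; within the scatter), so the two numbers cannot be told apart. In this one pair, a group of 8 heavy atoms with 2 hydrogen-bond acceptors replaces a carbon-only ring with none, and, unlike the large step on the carbonyl carbon, this swap stays within the scatter. Nothing at hand explains this result.

On these data alone, it remains open whether other groups on the sulfonyl sulfur, such as a pyrazole carrying a longer chain, an amine or a carboxylic acid, would also stay within the scatter. A single pair also cannot show whether this swap would give the same result with the group on the carbonyl carbon of compound 1.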